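The source may report more compounds than this note shows. Statements on the series, on what has been measured and on what is new or still open speak of the compounds shown alone.

In an ADME assay on cells (Erythrocyte, Homo sapiens), read by spectrophotometry and hemolysis, with a stated time of 24 h (on this read-out lower numbers stand for stronger inhibition and higher numbers for weaker inhibition), compound 1 (`O=Cc1ccccc1OCc1ccc2no[n+]([O-])c2c1`) shows only a limit of > 100 uM and no number. Compound 2 (`CC(=O)c1ccccc1OCc1ccc2no[n+]([O-])c2c1`) also shows only a limit, here > 200 uM and again no number. For the measured compounds named here, compound 3 (`NC(=S)N/N=C\c1ccccc1OCc1ccc2no[n+]([O-])c2c1`) gives 189 uM as the only number in the set. Compound 4 (`[O-][n+]1onc2ccc(COc3ccccc3/C=N\NC(=S)Nc3ccccc3)cc21`) has phenyl in place of hydrogen on an amide-type nitrogen, with phenyl in place of hydrogen on an amide-type nitrogen as the counted difference. The measured steps offer little guidance: there is a step that the two limits leave unreadable from compound 1 to compound 2 and a step that the limit leaves unreadable from compound 1 to compound 3 as well as an at least 1.0-fold lower number from compound 2 to compound 3 (0.02 log units; that floor lies within the scatter) to go on, and none of them changes that nitrogen. No step beyond the scatter is therefore expected in this assay for this change. An estimated 1.5-fold lower number from compound 3 to compound 4 (0.16 log units; within the scatter) is what is expected. For compound 4 the expected value is 130 uM with an estimated range from 40 uM to 300 uM in this test.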

Compound 4, concentration for 50% inhibition: > 200 uM
Compound 4: a limit, no number; the forecaster's own chance of this, stated with the estimate: 35%; middle value at least 1.5-fold (0.18 log units) from the limit.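

In this assay compound 4 gives only a limit, > 200 uM, and not a number. Phenyl in place of hydrogen on the amide-type nitrogen, the first change shown at this nitrogen, gives an at least 1.0-fold higher number from compound 3 to compound 4 (0.02 log units; that floor lies within the scatter), so only a floor for the step is known and its true size stays hidden. The same limit recurs in this small set: the limit of > 200 uM in this assay, at which 2 of the 4 values shown sit.

Only hydrogen and phenyl are shown on this nitrogen. On these data alone, whether a methyl group or a longer chain there would give a readable number remains open.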